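The source may hold more compounds than are shown below. What is called first, only, known or untested is meant among the compounds shown, and "the series" means these compounds.

Working notes on the series. Among the compounds with values here, compound 2 `CCc1cc(C(C)=O)c(OC(C)c2ccccc2)cc1OCCCCCC(C)(C)c1nnn[nH]1` gives 1700 nM in an assay on isolated protein for antagonist activity at Bile acid receptor (Homo sapiens), read by HTRF, with a stated time of 30 min (on this read-out higher numbers stand for weaker inhibition and lower numbers for stronger inhibition), the higher of the two numbers so far; compound 1 `CCc1cc(C(C)=O)c(OCc2ccccc2)cc1OCCCCCC(C)(C)c1nnn[nH]1` gives 1100 nM, and the step of a 1.5-fold higher number from compound 1 to compound 2 (0.19 log units; within the scatter) keeps the two within the scatter. Compound 3 `CCc1cc(C(C)=O)c(OC2CCCC2)cc1OCCCCCC(C)(C)c1nnn[nH]1` is not yet measured; it differs from compound 2 by cyclopentyl in place of 1-phenylethyl on an oxygen on an aromatic ring. Within the data shown here, no measured step touches the oxygen-bound group in this way: the only step known, a 1.5-fold higher number from compound 1 to compound 2 (0.19 log units; within the scatter), concerns a methyl added on the chain carbon bound to the aromatic ring and the oxygen and stayed within the scatter. The rest of the core, including the six-carbon chain to the tetrazole, is unchanged. On this basis no step beyond the scatter is expected in this assay, in either direction, for the move from compound 2 to compound 3, and the estimated step of no change at the digits printed from compound 2 to compound 3 (within the scatter) reflects that. Compound 3 is therefore expected at about 1700 nM, within 700 nM to 4500 nM.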

Compound 3, half-maximal inhibitory concentration: 3300 nM
Beside the measured number, compound 3's estimate is 1.9-fold (0.29 log units) below it; the range from low to high includes it.
By their numbers in this assay, from the lowest: compounds 1, 2 and 3 (each within the scatter of the next, the first and the last beyond it).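

In this assay, cyclopentyl in place of 1-phenylethyl on an oxygen on an aromatic ring gives a 1.9-fold higher number from compound 2 to compound 3 (0.29 log units; within the scatter), so at this position a group without an aromatic ring can stand in for 1-phenylethyl with no step beyond the scatter. Cyclopentyl in place of benzyl gives a 3.0-fold higher number from compound 1 to compound 3 (0.48 log units; beyond the scatter), the first step in the series beyond the scatter, though modest, which shows that the number does respond to the group on this oxygen. Nothing at hand explains the size of either step. The compounds shown leave open how a pyridylmethyl group, a cyclohexyl group or a benzyl carrying fluorine on its ring would read at this position. From the compounds shown here alone, whether the same steps hold with a carboxylic acid in place of the tetrazole also remains open.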